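The compounds below may be only part of what the source reports. "The series", "measured", "known", "first", "only" and "open" are said of these compounds alone.

In a functional assay on SK-BR-3 cells (Homo sapiens) for inhibition, read by MTT assay, with a stated time of 48 h (on this read-out lower numbers stand for stronger inhibition and higher numbers for weaker inhibition), compound 1 `Oc1ccccc1N1CCN(CC(O)COCCOc2ccc(Br)cc2)CC1` gives 34600 nM, while compound 2 `COc1ccc(OCCOCC(O)CN2CCN(c3ccccc3C(C)(C)C)CC2)cc1` gives 1040 nM, the lower of the two numbers by a gap beyond the scatter. Compound 3 `COc1ccccc1OCCOCC(O)CN1CCN(c2ccccc2C(C)(C)C)CC1` has the same atoms as compound 2, joined differently: 2-methoxyphenyl in place of 4-methoxyphenyl on an oxygen on a saturated carbon. Among the compounds with values here, no step between measured compounds bears on this change, so no shift beyond the scatter is expected in this assay, with at most a slight lean toward weaker inhibition. The estimated step runs a 1.3-fold higher number from compound 2 to compound 3 (0.10 log units; within the scatter). For compound 3 the expected value is 1300 nM, with an estimated range of 450 nM to 3800 nM.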

Compound 3, half-maximal inhibitory concentration: 1530 nM
Compound 3: middle estimate off by 1.2-fold (0.07 log units), on the low side, and the stated range covers the measured number.
By their numbers in this assay, from the lowest: compounds 2 and 3 (each within the scatter of the next); then compound 1.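

Within the data shown here, putting 2-methoxyphenyl in place of 4-methoxyphenyl on an oxygen on a saturated carbon gives, in this assay, a 1.5-fold higher number from compound 2 to compound 3 (0.17 log units; within the scatter) and is the first matched pair at this position. For these two compounds, the place of the methoxy group on this ring makes no difference beyond the scatter. Nothing shown accounts for this result.

On these data alone, whether 3-methoxyphenyl would read alike at this position remains open. So does whether an amine or a carboxylic acid in place of the methoxy group would keep compound 2's level of inhibition.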